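This account rests on a few compounds, and the source may have more. Where it says the series, first, only, none or still open, it means among the compounds named here.

Measured in this series:
- compound 1, `COC(=O)c1ccc(NCc2cncn2Cc2cccc(Cl)c2)cc1-c1ccccc1`: > 10000 nM
- compound 2, `c1ccc(-c2ccc(Cn3cncc3CNc3ccccc3-c3ccccc3)cc2)cc1`: > 10000 nM

In a toxicity assay on NIH3T3 cells (Mus musculus) for cytotoxicity, read by resazurin assay (on this read-out higher numbers stand for an effect only at larger amounts of compound and lower numbers for an effect already at smaller amounts), compound 1 gives > 10000 nM, which is a limit of the assay and not a number. Compound 2 in this assay likewise gives > 10000 nM, again a limit rather than a number. Compound 1 therefore stands where everything measured so far stands: the limit of > 10000 nM in this assay, at which 2 of the 2 values shown sit. Among the compounds with values here, no step between two measured compounds that differ in a single place is available, so the only guide for the next compound is the common position at the limit.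

Compound 3, `COC(=O)c1ccc(NCc2cncn2Cc2cccc([N+](=O)[O-])c2)cc1-c1ccccc1`, differs from compound 1 in one place: nitro in place of chloro on an aromatic carbon. Within the data shown here, with both measured values sitting at the limit, no step in this assay beyond the usual scatter is expected in either direction; the measurement for compound 3 is most likely to come back as a limit again. Compound 3 is accordingly estimated at 15000 nM, within a range of 7000 nM to 40000 nM. The expected step that the limit leaves unreadable from compound 1 to compound 3 is taken as none beyond the scatter.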

Compound 3, half-maximal effective concentration: > 10000 nM
Compound 3: no number, only a limit (the forecaster's own chance of this, stated with the estimate: 75%); the middle value does not contradict the limit.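

Between compound 1 and compound 3, in this assay no step can be read for nitro in place of chloro, since both values are limits and not numbers: the limit of > 10000 nM in this assay, at which 3 of the 3 values shown sit.

The compounds shown leave open at what concentration any of them would affect these cells, and whether nitro in place of chloro shifts that concentration.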